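Aryl variation on the enone arm: compound 4

The compounds below may be only part of what the source reports. "The series", "measured", "known", "first", "only" and "open" are said of these compounds alone.

Compound 1 `CNC(=O)c1cc(Oc2ccc(C(=O)/C=C/c3cccc(Br)c3)cc2)ccn1` carries a 3-bromophenyl on a double-bonded chain carbon bound to a double-bonded chain carbon. In a functional assay on PC-3 cells (Homo sapiens) for cytotoxicity, read by MTT assay, with a stated time of 72 h (a higher number here means a weaker inhibitor, a lower number a stronger inhibitor), compound 1 gives 3400 nM, the lowest of the three numbers recorded, though not separated from all of them. Compound 3 `CNC(=O)c1cc(Oc2ccc(C(=O)/C=C/c3ccc(F)cc3Cl)cc2)ccn1` gives 4760 nM and compound 2 `CNC(=O)c1cc(Oc2ccc(C(=O)/C=C/c3ccc([N+](=O)[O-])cc3)cc2)ccn1` gives 11100 nM. The step of a 1.4-fold higher number from compound 1 to compound 3 (0.15 log units; within the scatter) stays within the scatter, whereas a 3.3-fold higher number from compound 1 to compound 2 (0.51 log units; beyond the scatter) and a 2.3-fold lower number from compound 2 to compound 3 (0.37 log units; beyond the scatter) lie beyond it.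

Compound 4 `CNC(=O)c1cc(Oc2ccc(C(=O)/C=C/c3ccc(Cl)cc3Cl)cc2)ccn1` has not yet been measured. Relative to compound 1 the change is 2,4-dichlorophenyl in place of 3-bromophenyl on a double-bonded chain carbon bound to a double-bonded chain carbon. Among the compounds with values here, the only measured step of the same kind is a 1.4-fold higher number from compound 1 to compound 3 (0.15 log units; within the scatter); the other two steps involve 4-nitrophenyl and do not bear directly on this change. Because a 1.4-fold higher number from compound 1 to compound 3 (0.15 log units; within the scatter) stayed within the scatter for compound 3, the expected step of a 1.2-fold higher number from compound 1 to compound 4 (0.07 log units; within the scatter) is small, with no direction beyond the scatter. The estimate for compound 4 in this assay is 4000 nM, expected to fall between 1800 nM and 9000 nM.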

Compound 4, half-maximal inhibitory concentration: 9220 nM
Beside the measured number, compound 4's estimate is 2.3-fold (0.36 log units) below it; measured number outside the range, above it.
By their numbers in this assay, from the lowest: compounds 1, 3, 4 and 2 (each within the scatter of the next, the first and the last beyond it).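

In this assay the step of a 2.7-fold higher number from compound 1 to compound 4 (0.43 log units; beyond the scatter) lies beyond the scatter, so an aryl group carrying two halogens on this double-bonded chain carbon can separate from 3-bromophenyl, which 2-chloro-4-fluorophenyl in compound 3 did not do. Chloro in place of fluoro on an aromatic carbon gives a 1.9-fold higher number from compound 3 to compound 4 (0.29 log units; within the scatter) and 2,4-dichlorophenyl in place of 4-nitrophenyl gives a 1.2-fold lower number from compound 2 to compound 4 (0.08 log units; within the scatter) and both steps stay within the scatter, so compound 4 is separated from neither compound 3 nor compound 2, even though those two are separated from each other. No available measurement explains these differences.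

Still open, on these data alone, is whether the reading of compound 1 depends on bromo itself or on where it sits on the phenyl ring. Also open, as far as these compounds go, is how a methoxyphenyl, a dimethylaminophenyl or a pyridyl group at this position would read in this assay against the halogen-bearing aryl groups.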